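Acetyl in place of fluoro: the step from compound 3 to compound 4

This account rests on a few compounds, and the source may have more. Where it says the series, first, only, none or still open, it means among the compounds named here.

Measured compounds:
Compound 1, `COc1ccc(-c2cn3ccnc3c(-c3ccc4ncn(C5CCCCC5)c4c3)n2)cc1`: 80.2%
Compound 2, `O=Cc1ccc(-c2cn3ccnc3c(-c3ccc4ncn(C5CCCCC5)c4c3)n2)cc1`: 47.8%
Compound 3, `Fc1ccc(-c2cn3ccnc3c(-c3ccc4ncn(C5CCCCC5)c4c3)n2)cc1`: 9.17%

Of the compounds shown here, three sharing one core have been measured in a functional assay on MCF7 cells (Homo sapiens) for inhibition, read by sulforhodamine B assay, with a stated time of 48 h, tested at 10 uM; a higher number here means more inhibition at the concentration tested (going by the name of the read-out), a lower number less inhibition. Compound 1 gives 80.2%, compound 2 gives 47.8%, and compound 3 gives 9.17%. Compound 3 stands lowest of the three; the nearest is compound 2, and the steps to both others are beyond the scatter: a number 38.6 percentage points lower from compound 2 to compound 3 (beyond the scatter) and a number 71 percentage points lower from compound 1 to compound 3 (beyond the scatter).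

The next compound, compound 4, `CC(=O)c1ccc(-c2cn3ccnc3c(-c3ccc4ncn(C5CCCCC5)c4c3)n2)cc1`, has not been measured. It differs from compound 3 in one place: acetyl in place of fluoro on an aromatic carbon.

Among the measured compounds shown here, the step that bears most directly on this change is the one between compound 2 and compound 3, a number 38.6 percentage points lower from compound 2 to compound 3 (beyond the scatter), since the formyl group of compound 2 and the acetyl group of compound 4 both carry a carbonyl at the same place on the ring. Read in reverse, that step suggests that putting a carbonyl-bearing group back in place of fluoro should raise the number by a large amount. The step from compound 1 to compound 3, a number 71 percentage points lower from compound 1 to compound 3 (beyond the scatter), shows that a change at the same position has given an even larger swing in the number.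

A rise beyond the scatter is therefore expected, estimated as a number 35.8 percentage points higher from compound 3 to compound 4 (beyond the scatter). Compound 4 is expected to give about 45%, with a likely range from 20% to 70%.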

Compound 4, a percentage reported as inhibition, at one concentration (the size of the read-out at that concentration, not a potency): 12%
Compound 4: middle estimate off by 33 percentage points, on the high side; measured number below the stated range.
By their numbers in this assay, from the lowest: compounds 3 and 4 (each within the scatter of the next); then compound 2; then compound 1.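

In this assay a carbonyl on this aromatic carbon, para to a large group, is not enough to keep the number up: methyl in place of hydrogen on the carbonyl carbon gives a number 35.8 percentage points lower from compound 2 to compound 4 (beyond the scatter) and so shows that this position responds strongly to a change made on the carbonyl group itself. Acetyl in place of fluoro gives a number 2.8 percentage points higher from compound 3 to compound 4 (within the scatter) and places these two groups together at the low end, although they share neither size nor a hydrogen-bond acceptor. Acetyl in place of methoxy gives a number 68.2 percentage points lower from compound 1 to compound 4 (beyond the scatter) and so leaves formyl and methoxy as the only groups of the four that stand clear of that low pair.

No evidence at hand explains why formyl and acetyl part so sharply, or why methoxy stands highest. The compounds shown leave open whether the high number belongs to the methoxy group in particular or would also be reached with a hydroxyl, an ethoxy group or a dimethylamino group at this place.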